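This account rests on a few compounds, and the source may have more. Where it says the series, first, only, none or still open, it means among the compounds named here.

Measured compounds in an ADME assay on L1210/0 cells (Mus musculus) for cytotoxicity, with a stated time of 48 h; on this read-out lower numbers stand for stronger inhibition and higher numbers for weaker inhibition:

Compound 1, `O=c1[nH]c(=O)n([C@H]2C[C@H](O)[C@@H](CO)O2)cc1CO`, gives 9180 nM.
Compound 2, `N#CSc1cn([C@H]2C[C@H](O)[C@@H](CO)O2)c(=O)[nH]c1=O`, gives 78900 nM.
Compound 3, `O=c1[nH]c(=O)n([C@H]2C[C@H](O)[C@@H](CO)O2)cc1C#CCCO`, gives only a limit of the assay, > 200000 nM.

Compound 3 is thus the weakest of the three measured compounds: the step of an at least 21-fold higher number from compound 1 to compound 3 (1.33 log units; beyond the scatter) is large and the step of an at least 2.5-fold higher number from compound 2 to compound 3 (0.40 log units; beyond the scatter) is at least modest, both beyond the scatter. The step of an 8.6-fold higher number from compound 1 to compound 2 (0.93 log units; beyond the scatter) is modest. Every replacement of the hydroxymethyl on the aromatic carbon so far has weakened inhibition, and the 4-hydroxybut-1-yn-1-yl compound sits at the limit (the limit of > 200000 nM in this assay, at which 1 of the 3 values shown sits).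

Compound 4, `CC(C)(C)C#Cc1cn([C@H]2C[C@H](O)[C@@H](CO)O2)c(=O)[nH]c1=O`, differs from compound 3 as follows: tert-butyl in place of 2-hydroxyethyl on a triple-bonded carbon. For the measured compounds named here, no measured step touches a substituent on the triple-bonded carbon, so none bears directly on this change; the measured steps only show that compound 3 already lies at the limit. The expectation for the step that the limit leaves unreadable from compound 3 to compound 4 is therefore no move beyond the scatter, with compound 4 most likely reported as a limit again. The estimated value for compound 4 is 250000 nM, in the range 60000 nM to 1000000 nM.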

Compound 4, half-maximal inhibitory concentration: > 200000 nM
Compound 4 ended at the assay's limit; the forecaster's own chance of this, stated with the estimate: 70%; the middle value is on the limit's open side.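

For the compounds shown here, measured against the earlier compounds, 3,3-dimethylbut-1-yn-1-yl in place of hydroxymethyl gives an at least 21-fold higher number from compound 1 to compound 4 (1.33 log units; beyond the scatter), and in place of cyanosulfanyl it gives an at least 2.5-fold higher number from compound 2 to compound 4 (0.40 log units; beyond the scatter). Weak inhibition at this position therefore no longer rests on 4-hydroxybut-1-yn-1-yl alone: with tert-butyl in place of 2-hydroxyethyl on the triple-bonded carbon, removing the hydroxyl-bearing chain does not bring the read-out back inside the measurable range of this assay. The step between compound 3 and compound 4 cannot be read, so any difference between these two substituents stays hidden, because both compounds sit at a limit and not at a number: the limit of > 200000 nM in this assay, at which 2 of the 4 values shown sit.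

As far as these compounds go, whether any group on a triple bond at the aromatic carbon can keep a measurable value stays open, for instance a plain ethynyl or a short propynyl chain ending in an amine. Also open, from the compounds shown here alone, is whether the loss follows the triple bond or the chain length, a question that a saturated butyl chain in the same place would help to separate.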